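Swapping Bromo for Methoxy on a Shared Core

The compounds below may be only part of what the source reports. "The series", "measured", "known", "first", "only" and "open" are said of these compounds alone.

Four compounds share a fused, partly saturated core and were examined in an assay on isolated protein for inhibition of glucose-6-phosphatase catalytic subunit 1 (Homo sapiens), read by inositol phosphate accumulation, with a stated time of 30 min, tested at 100 uM; a higher number here means more inhibition at the concentration tested (going by the name of the read-out), a lower number less inhibition. Compound 1, `CCOC(=O)C1(O)CC(c2ccc(Br)cc2)C2=C(CC(C)(C)CC2=O)O1`, carries a bromo group on its phenyl ring; in this assay compound 1 gives "not active" (no number reported), so no single number stands for it. Compound 2, `Cc1ccc(C2=CC(c3ccccc3)C3=C(CC(C)(C)CC3=O)N2)cc1`, is similar in this respect: in this assay compound 2 gives "not active" (no number reported). Within the data shown here, compound 3, `O=C1CCCC2=C1C(c1ccc(Cl)cc1)C=C(c1ccccc1)N2`, is the only one of the measured compounds with a number: in this assay compound 3 gives 8.21%, a low figure at the concentration tested.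

Compound 4, `CCOC(=O)C1(O)CC(c2ccc(OC)cc2)C2=C(CC(C)(C)CC2=O)O1`, differs from compound 1 in one place: methoxy in place of bromo on an aromatic carbon. The change sits on an aromatic carbon of a six-membered aromatic ring of carbon only, para to a large group, and brings one hydrogen-bond acceptor where there was none.

Among the measured compounds shown here, no measured pair here shows what such a change does on this core, and compound 1 itself has no number to start from. The step from compound 1 to compound 4 in this assay is expected to stay within the scatter, with no clear direction. Compound 4 is estimated to give 5%, in the range from -10% to 20%.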

Compound 4, a percentage reported as inhibition, at one concentration (the size of the read-out at that concentration, not a potency): "not active" (no number reported)
Compound 4 has no reported number here, so the estimate cannot be set against anything.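

In this assay, among these compounds, compound 1 gives "not active" (no number reported) and compound 4 gives "not active" (no number reported) so no step between them can be read. No measurement here offers an explanation for these results. On these data alone, whether changing 4-bromophenyl to 4-methoxyphenyl alters inhibition on the shared core remains open.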